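Swapping the Ether's Fluorinated Arm for a Small Ring

The source may hold more compounds than are shown below. What is called first, only, known or untested is meant among the compounds shown, and "the series" means these compounds.

Of the compounds shown here, two sharing one core have been measured in an assay on mitochondria from L6 cells (Rattus norvegicus) for activation, with a stated time of 90 min; a higher number here means that more compound is needed for the effect, a lower number that less compound is needed. Compound 1 `Oc1nc2nonc2nc1Nc1ccc(OCC(F)(F)F)c(F)c1` gives 10400 nM. Going by the values given here, compound 2 `Oc1nc2nonc2nc1Nc1ccc(OCC(F)(F)F)c(C(F)(F)F)c1` gives 4000 nM, the lower of the two numbers, and the only measured step, a 2.6-fold lower number from compound 1 to compound 2 (0.41 log units; beyond the scatter), separates them. Compound 3 `Oc1nc2nonc2nc1Nc1ccc(OCC2CC2)c(C(F)(F)F)c1` is not yet measured; it differs from compound 2 by cyclopropyl in place of trifluoromethyl on a saturated chain carbon bound to an oxygen on an aromatic ring. Among the compounds with values here, that change sits on a different part of the molecule from the measured step, which alters a group on the aromatic ring, so no measured step bears on it and it offers no guide to direction. The expectation for compound 3 is therefore a small shift at most, likely within the scatter, with no change at the digits printed from compound 2 to compound 3 (within the scatter) as the expected step. Compound 3 is estimated at 4000 nM, with a plausible range from 1500 nM to 12000 nM in this assay.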

Compound 3, half-maximal effective concentration: 1800 nM
Compound 3: the middle estimate sits 2.2-fold (0.35 log units) above what was measured, and the stated range covers the measured number.
By their numbers in this assay, from the lowest: compound 3; then compound 2; then compound 1.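

In this assay the change from a 2,2,2-trifluoroethyl arm on the ether oxygen to a cyclopropylmethyl arm gives a 2.2-fold lower number from compound 2 to compound 3 (0.35 log units; beyond the scatter) and so shows that this part of the molecule also affects the number, not only the group on the aromatic ring. The fluorines of the arm are also not required for a low number in this series, as the arm of compound 3 holds only carbon and hydrogen. No measurement at hand explains the shift.

Still open, going by these compounds, is whether the three-membered ring itself matters, or whether an open chain such as a propyl or butyl group would serve equally well, and how an arm carrying an amine would behave. The compounds shown also leave open whether the same swap would lower the number with fluoro in place of trifluoromethyl on the aromatic ring.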